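A few compounds are considered here, and "the series" means these few. Any claim that something is new, unique, unknown or untested is made for them only; others in the source may bear on it.

Measured in an ADME assay (liver, Mus musculus) for metabolic stability, using microsomes; a higher number here means that the compound lasts longer, a lower number that the compound disappears faster:
compound 1 `C=CC(=O)Nc1cccc(CNc2nc(Nc3cnn(CC(=O)N4CCOCC4)c3)ncc2Cl)c1`: 0.12 h
compound 2 `C=CC(=O)Nc1cccc(CNc2nc(Nc3cnn(CCOC)c3)ncc2Cl)c1`: 0.055 h

Of these two, compound 2 stands lowest, at 0.055 h. Compound 3 `C=CC(=O)Nc1cccc(C(C)Nc2nc(Nc3cnn(CCOC)c3)ncc2Cl)c1` is still unmeasured and differs from compound 2 by methyl in place of hydrogen on a saturated chain carbon bound to an aromatic carbon and a nitrogen on an aromatic ring.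

Within the data shown here, the only measured step, a 2.2-fold lower number from compound 1 to compound 2 (0.34 log units; beyond the scatter), is modest and lies elsewhere, on a saturated chain carbon bound to an aromatic nitrogen. Among the measured compounds shown here, it gives a rough size for a single change but no direction for this one, and no measured step covers the place changed here. No step beyond the scatter is therefore expected in this assay.

The expected change is a 1.1-fold higher number from compound 2 to compound 3 (0.04 log units; within the scatter).

The estimate for compound 3 is 0.06 h, with an expected range from 0.03 h to 0.12 h.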

Compound 3, half-life: 0.0433 h
Compound 3: the middle estimate sits 1.4-fold (0.14 log units) above what was measured; the range from low to high includes it.
By their numbers in this assay, from the lowest: compounds 3 and 2 (each within the scatter of the next); then compound 1.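

In this assay, methyl in place of hydrogen on a saturated chain carbon bound to an aromatic carbon and a nitrogen on an aromatic ring gives a 1.3-fold lower number from compound 2 to compound 3 (0.10 log units; within the scatter) and so leaves no readable effect on the half-life. Among these compounds, this is the first measured step at this place, since the earlier pair covered only a saturated chain carbon bound to an aromatic nitrogen, and a 2.2-fold lower number from compound 1 to compound 2 (0.34 log units; beyond the scatter) remains the only step here beyond the scatter. No evidence on the cause of this result is at hand.

Going by these compounds, whether ethyl or cyclopropyl on this same carbon would move the number in this assay beyond the scatter remains open. Also open, on these data alone, is whether methyl at this place would read the same with (morpholin-4-yl)carbonyl instead of methoxymethyl on the other chain.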